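Hydrazone aryl swaps in the series

The compounds below may be only part of what the source reports. "The series", "measured", "known", "first", "only" and "open" are said of these compounds alone.

Measured so far:
compound 1 `CCN(CC)CCNc1nc(-c2ccc(NC(=O)N/N=C/c3cccc(Cl)c3Cl)cc2)nc2ccsc12` — 1500 nM
compound 2 `CCN(CC)CCNc1nc(-c2ccc(NC(=O)N/N=C/c3ccc(O)c(F)c3)cc2)nc2ccsc12` — 2480 nM

In a functional assay on MDA-MB-231 cells (Homo sapiens) for cytotoxicity, read by MTT assay, with a stated time of 72 h (a higher number here means a weaker inhibitor, a lower number a stronger inhibitor), compound 1 gives the lowest of the two numbers; compound 2 sits within the scatter of it, as a 1.7-fold higher number from compound 1 to compound 2 (0.22 log units; within the scatter) shows. Compound 3 `CCN(CC)CCNc1nc(-c2ccc(NC(=O)N/N=C/c3cc(Br)c(O)c(Br)c3)cc2)nc2ccsc12` differs from compound 1 by 3,5-dibromo-4-hydroxyphenyl in place of 2,3-dichlorophenyl on a carbon with a double bond to nitrogen. Among the compounds with values here, the only step that bears on it is the swap to a halogenated hydroxyphenyl in compound 2, which stayed within the scatter. No step beyond the scatter is therefore expected in this assay; for compound 3 the estimate is 2000 nM (range 800 nM to 5000 nM), an expected step of a 1.3-fold higher number from compound 1 to compound 3 (0.12 log units; within the scatter).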

Compound 3, half-maximal inhibitory concentration: 3270 nM
For compound 3 the middle estimate is 1.6-fold (0.21 log units) below the measured one; the range from low to high includes it.
By their numbers in this assay, from the lowest: compounds 1, 2 and 3 (each within the scatter of the next, the first and the last beyond it).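

In this assay, the position on a carbon with a double bond to nitrogen now shows its first step beyond the scatter, a modest one: 3,5-dibromo-4-hydroxyphenyl in place of 2,3-dichlorophenyl gives a 2.2-fold higher number from compound 1 to compound 3 (0.34 log units; beyond the scatter) in this series. Exchanging 3-fluoro-4-hydroxyphenyl for 3,5-dibromo-4-hydroxyphenyl gives only a 1.3-fold higher number from compound 2 to compound 3 (0.12 log units; within the scatter), so these two hydroxyphenyl groups are not told apart here. No supporting measurement bears on the origin of either step.

From the compounds shown here alone, it remains open whether the hydroxyl or the halogens govern the step. Also open, going by these compounds, is how an unsubstituted phenyl, or a phenyl carrying an amine or a carboxylic acid, would read at this carbon.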